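The source may report more compounds than this note shows. Statements on the series, on what has been measured and on what is new or still open speak of the compounds shown alone.

Three members of this series have been measured in an ADME assay on L02 cells (Homo sapiens) for cytotoxicity, read by MTT assay, with a stated time of 24 h; on this read-out higher numbers stand for weaker inhibition and lower numbers for stronger inhibition. Compound 1 `O=C1/C(=C/c2cccc([N+](=O)[O-])c2)CN(S(=O)(=O)c2ccc(F)cc2)C/C1=C\c1ccccc1F` gives 17000 nM in this assay. Compound 2 `N#Cc1ccc(/C=C2\CN(S(=O)(=O)c3ccc(F)cc3)C/C(=C\c3ccccc3F)C2=O)cc1` gives 21900 nM, and compound 3 `CC(=O)Nc1ccc(S(=O)(=O)N2C/C(=C\c3cccc([N+](=O)[O-])c3)C(=O)/C(=C/c3ccccc3F)C2)cc1` gives 18400 nM. Replacing 3-nitrophenyl with 4-cyanophenyl made a 1.3-fold higher number from compound 1 to compound 2 (0.11 log units; within the scatter), and replacing fluoro with acetamido made a 1.1-fold higher number from compound 1 to compound 3 (0.03 log units; within the scatter). Within the data shown here, compound 2 and compound 3 have no direct step recorded; their two values lie close together, and no ordering among the three is supported.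

Compound 4 `CC(=O)Nc1ccc(S(=O)(=O)N2C/C(=C\c3ccc(C#N)cc3)C(=O)/C(=C/c3ccccc3F)C2)cc1` remains to be measured in this assay. It differs from compound 3 by 4-cyanophenyl in place of 3-nitrophenyl on a double-bonded chain carbon bound to a double-bonded ring carbon. The same change separates compound 1 from compound 2, namely (4-cyanophenyl in place of 3-nitrophenyl on a double-bonded chain carbon bound to a double-bonded ring carbon), and the place is described in identical words, so it counts as the same change. The two cores on which it is made differ by acetamido in place of fluoro on an aromatic carbon.

The step from compound 3 to compound 4 is expected to be a 1.3-fold higher number from compound 3 to compound 4 (0.10 log units; within the scatter), resting on the earlier 1.3-fold higher number from compound 1 to compound 2 (0.11 log units; within the scatter), which was within the scatter. Compound 4 is estimated at 23000 nM, with a range from 12000 nM to 45000 nM.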

Compound 4, half-maximal inhibitory concentration: 14400 nM
Compound 4: the middle estimate sits 1.6-fold (0.20 log units) above what was measured; low and high end bracket the measured number.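

In this assay, the change to 4-cyanophenyl on the core of compound 3 gives a 1.3-fold lower number from compound 3 to compound 4 (0.11 log units; within the scatter), and set beside the earlier step on the core of compound 1 it shows no difference beyond the scatter: the same change on two cores in this assay, a 1.3-fold higher number (0.11 log units; within the scatter) from compound 1 to compound 2 and a 1.3-fold lower number (0.11 log units; within the scatter) from compound 3 to compound 4, 1.6-fold (0.22 log units) apart, within the scatter of two such steps

The change from fluoro to acetamido, now read on the 4-cyanophenyl core, gives a 1.5-fold lower number from compound 2 to compound 4 (0.18 log units; within the scatter), and again the two steps do not differ beyond the scatter: the same change on two cores in this assay, a 1.1-fold higher number (0.03 log units; within the scatter) from compound 1 to compound 3 and a 1.5-fold lower number (0.18 log units; within the scatter) from compound 2 to compound 4, 1.6-fold (0.22 log units) apart, within the scatter of two such steps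

Both changes therefore carry across these two cores without a detectable difference, but with every step inside the scatter this does not show that either change has a real effect here, that the opposite signs of the paired steps mean anything, or that one pair of cores sets a rule for the series.

Going by these compounds, whether any replacement at these two places can move the number beyond the scatter remains open. A carboxylic acid or an amine in place of acetamido, or a methoxy group in place of the nitrile, would test this.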